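The compounds below may be only part of what the source reports. "The series", "measured", "known", "first", "only" and "open" are said of these compounds alone.

Measured in a functional assay on A-375 cells (Homo sapiens) for cytotoxicity, read by MTT assay, with a stated time of 72 h; on this read-out lower numbers stand for stronger inhibition and higher numbers for weaker inhibition:
- compound 1 `O=C1c2c[n+]([O-])c3ccccc3c2C(=O)c2c1c1ccccc1n2Cc1cn(C[C@H](O)CO)nn1`: 350 nM
- compound 2 `CN1CCN(CCCCn2c3c(c4ccccc42)C(=O)c2c[n+]([O-])c4ccccc4c2C3=O)CC1`: 30 nM

Of these two, compound 2 has the lower number, at 30 nM. Compound 3 `O=C1c2c[n+]([O-])c3ccccc3c2C(=O)c2c1c1ccccc1n2CCCCN1CCNCC1` differs from compound 2 by hydrogen in place of methyl on an amine nitrogen in a ring. For the measured compounds named here, the only measured step, a 12-fold lower number from compound 1 to compound 2 (1.07 log units; beyond the scatter), is large but replaces the whole side group. Going by the values given here, it sets no size for this much smaller change, which no measured pair isolates. No shift beyond the scatter is expected in this assay. The expected step is a 1.3-fold higher number from compound 2 to compound 3 (0.12 log units; within the scatter). Compound 3 is estimated at 40 nM, with an expected range of 12 nM to 130 nM.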

Compound 3, half-maximal inhibitory concentration: 460 nM
Compound 3: the middle estimate sits 12-fold (1.06 log units) below what was measured, outside the stated range (above it).
By their numbers in this assay, from the lowest: compound 2; then compounds 1 and 3 (each within the scatter of the next).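

In this assay, a change of one heavy atom on the ring amine nitrogen is large: hydrogen in place of methyl gives a 15-fold higher number from compound 2 to compound 3 (1.19 log units; beyond the scatter). The piperazin-1-yl side group, without the methyl, stands level with the triazole side group, at a 1.3-fold higher number from compound 1 to compound 3 (0.12 log units; within the scatter). Among these compounds, the large gain of compound 2 therefore appears only with the 4-methylpiperazin-1-yl group, and no available evidence explains this.

Open, going by these compounds, is whether an ethyl or an acetyl on that ring nitrogen would hold the lower number. Also open, on these data alone, is how a shorter or longer chain would affect the 4-methylpiperazin-1-yl compound.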